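A Trifluoromethyl Group Enters Where Hydrogen Sat

The source may report more compounds than this note shows. Statements on the series, on what has been measured and on what is new or still open speak of the compounds shown alone.

Compound 3 `COc1ccc(C(=O)/C=C/c2ccccc2)c2c1C=CC(C)(C)O2` reaches only a limit in a functional assay on K562 cells (Homo sapiens) for antiproliferative activity, read by MTT assay, with a stated time of 24 h (a lower number here means a stronger inhibitor, a higher number a weaker inhibitor), reported as > 10000 nM. Compound 1 `COc1cccc(/C=C/C(=O)c2ccc(OC)c3c2OC(C)(C)C=C3)c1` likewise sits at a limit, giving > 10000 nM in this assay. Compound 2 `COc1ccc(C(=O)/C=C/c2cccc([N+](=O)[O-])c2)c2c1C=CC(C)(C)O2` gives a readable number in this assay, 5870 nM. Two of the three values thus share one limit, namely (the limit of > 10000 nM in this assay, at which 2 of the 3 values shown sit), so the shared core on its own does not reach a measurable number here. Compound 4 `COc1ccc(C(=O)/C=C/c2cccc(C(F)(F)F)c2)c2c1C=CC(C)(C)O2` differs from compound 3 by trifluoromethyl in place of hydrogen on an aromatic carbon, sitting on an aromatic carbon of a six-membered aromatic ring of carbon only, meta to a large group. For the measured compounds named here, no measured step swaps hydrogen for trifluoromethyl. The nearest guide is the step of an at least 1.7-fold higher number from compound 2 to compound 3 (0.23 log units; that floor lies within the scatter), in which a nitro group left that same ring; the step that the two limits leave unreadable from compound 1 to compound 3 offers no size. A group entering the ring gave a readable number once, so a modest move below the limit is expected for compound 4, though the limit may well be reached again. Compound 4 is expected at 6500 nM, within 2500 nM to 20000 nM. That corresponds to an expected step of an at least 1.5-fold lower number from compound 3 to compound 4 (0.18 log units; that floor lies within the scatter).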

Compound 4, half-maximal inhibitory concentration: 7850 nM
Estimate against measurement, compound 4: 1.2-fold (0.08 log units) below; measured number inside the range.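

Compound 4 is the second compound with a readable number in this assay, so a readable value at this position on the ring is no longer confined to nitro. Trifluoromethyl and nitro cannot be told apart here, as the swap between them gives a 1.3-fold higher number from compound 2 to compound 4 (0.13 log units; within the scatter). The other two comparisons start from limits and give only floors, an at least 1.2-fold lower number from compound 3 to compound 4 (0.10 log units; that floor lies within the scatter) and an at least 1.2-fold lower number from compound 1 to compound 4 (0.10 log units; that floor lies within the scatter), so neither establishes a real gain over hydrogen or methoxy.

On these data alone, whether any group at this position can bring the number well below these values remains open, and an amine or a carboxylic acid in this place would be an informative test. As far as these compounds go, how far hydrogen and methoxy truly lie from trifluoromethyl also stays unknown, since those compounds reach only a limit.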